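Ring Expansion of the Amine in Compound 2

This account rests on a few compounds, and the source may have more. Where it says the series, first, only, none or still open, it means among the compounds named here.

Compound 1 `O=C(O)c1cccc(Cc2c(-c3ccco3)nn3cc(Cl)ccc23)n1` gives 1200 nM in a functional assay on cells for antagonist activity at prostaglandin E2 receptor EP1 subtype (Rattus norvegicus), read by fluorescence and calcium flux, with a stated time of 60 s; on this read-out lower numbers stand for stronger inhibition and higher numbers for weaker inhibition.
Compound 2 `O=C(O)c1cccc(Cc2c(N3CCCC3)nn3cc(Cl)ccc23)n1` gives 1800 nM in this assay.

Among these two numbers compound 2 stands alongside compound 1, separated only by a 1.5-fold higher number from compound 1 to compound 2 (0.18 log units; within the scatter). Compound 3 `O=C(O)c1cccc(Cc2c(N3CCCCC3)nn3cc(Cl)ccc23)n1` differs from compound 2 by piperidin-1-yl in place of pyrrolidin-1-yl on an aromatic carbon. For the measured compounds named here, the single measured step, a 1.5-fold higher number from compound 1 to compound 2 (0.18 log units; within the scatter), concerns a different exchange at the same position and stays within the scatter, so no measured step bears directly on this ring enlargement. No shift beyond the scatter is expected in this assay. Compound 3 is therefore estimated at 2000 nM, within 700 nM to 6000 nM, an expected step of a 1.1-fold higher number from compound 2 to compound 3 (0.05 log units; within the scatter).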

Compound 3, half-maximal inhibitory concentration: 79 nM
Beside the measured number, compound 3's estimate is 25-fold (1.40 log units) above it, and the stated range ends above it.
By their numbers in this assay, from the lowest: compound 3; then compounds 1 and 2 (each within the scatter of the next).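

In this assay this position proves highly sensitive to the size of the saturated amine ring: piperidin-1-yl in place of pyrrolidin-1-yl gives a 23-fold lower number from compound 2 to compound 3 (1.36 log units; beyond the scatter). The earlier exchange of furan-2-yl for pyrrolidin-1-yl had stayed within the scatter, whereas piperidin-1-yl also stands clear of furan-2-yl, with a 15-fold lower number from compound 1 to compound 3 (1.18 log units; beyond the scatter). No measured evidence here accounts for this sharp difference between the two amine rings. Going by these compounds, whether azepan-1-yl or morpholin-4-yl on this aromatic carbon would keep the low number of compound 3 remains open.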